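A few compounds are considered here, and "the series" means these few. Any claim that something is new, unique, unknown or untested is made for them only; others in the source may bear on it.

Compounds measured in an assay on lysate for inhibition of phosphatidylcholine:ceramide cholinephosphotransferase 2 (Homo sapiens), read by HPLC, with stated times of 30 min and 2 h (a lower number here means a stronger inhibitor, a higher number a weaker inhibitor), so far:
compound 1, `O=C(NCc1ccccc1)c1ccccc1OCc1ccccc1`, gives 34200 nM
compound 2, `O=C(NCc1ccco1)c1ccccc1OCc1ccccc1`, gives 49000 nM
compound 3, `O=C(Nc1cccnc1)c1ccccc1OCc1ccccc1F`, gives 3500 nM

Compound 3 holds the lowest number of the three. The other two stand clearly higher: compound 1 is the nearer of them and compound 2 the further, and both gaps lie beyond the scatter. The single step measured within the set, a 1.4-fold higher number from compound 1 to compound 2 (0.16 log units; within the scatter), concerns the group on the saturated chain carbon bound to the amide-type nitrogen and stays within the scatter, so within this set that part of the molecule has so far shown no clear effect.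

Compound 4, `O=C(Nc1cccnc1)c1ccccc1OCc1cccc(Cl)c1`, differs from compound 3 by 3-chlorophenyl in place of 2-fluorophenyl on a saturated chain carbon bound to an oxygen on an aromatic ring. For the measured compounds named here, no measured step bears on this part of the molecule; the step from compound 1 to compound 2 changes a different group and gives no guide to direction or size here. With nothing in the set pointing one way or the other, compound 4 is expected to come out near compound 3, with no change at the digits printed from compound 3 to compound 4 (within the scatter) as the expected step, not beyond the scatter. For compound 4 in this assay the estimate is 3500 nM, with a range from 1200 nM to 10000 nM.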

Compound 4, half-maximal inhibitory concentration: 1400 nM
Compound 4: the middle estimate sits 2.5-fold (0.40 log units) above what was measured; the measured number falls inside the stated range.
By their numbers in this assay, from the lowest: compound 4; then compound 3; then compounds 1 and 2 (each within the scatter of the next).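

For the compounds shown here, replacing 2-fluorophenyl with 3-chlorophenyl on a saturated chain carbon bound to an oxygen on an aromatic ring gives a 2.5-fold lower number from compound 3 to compound 4 (0.40 log units; beyond the scatter) in this assay, so this part of the molecule, which the only earlier step did not touch, can move the read-out, though modestly. The two groups have the same heavy-atom count, the same counts of hydrogen-bond donors and acceptors, and no net charge, so the step appears with none of these counts changing; the halogen and its place on the ring change together, however, and this single pair cannot separate the two. Nothing available explains the step.

Still open, as far as these compounds go, is whether the halogen or its place on the ring carries the step, and whether a plain phenyl, a methoxyphenyl or a phenyl bearing a carboxylic acid or an amine at this same place would keep, lose or extend it. Going by these compounds alone, it is also open whether 3-chlorophenyl has a similar effect when the group on the amide nitrogen is the one in compound 1 or compound 2.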